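Chain-length variation on a silyl-protected tetrahydropyran series

The compounds below may be only part of what the source reports. "The series", "measured", "known", "first", "only" and "open" are said of these compounds alone.

Measured so far:
compound 1 `CC(C)(C)[Si](C)(C)O[C@H]1CCCO[C@@H]1CC=O` — 40000 nM
compound 2 `CC(C)(C)[Si](C)(C)O[C@H]1CCCO[C@@H]1C/C=C/CO` — 27000 nM

Notes. In a functional assay on HL-60 cells (Homo sapiens) (a higher number here means a weaker inhibitor of growth, a lower number a stronger inhibitor of growth), compound 1 gives 40000 nM and compound 2 gives 27000 nM. Going by the values given here, the only measured step, a 1.5-fold lower number from compound 1 to compound 2 (0.17 log units; within the scatter), is within the scatter, so compound 2 and compound 1 are not distinguished by these numbers; compound 2 simply stands alongside compound 1 with nothing beyond the scatter between them.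

Compound 3 `CC(C)(C)[Si](C)(C)O[C@H]1CCCO[C@@H]1/C=C/CO` differs from compound 2 by 3-hydroxyprop-1-en-1-yl in place of 4-hydroxybut-2-en-1-yl on a saturated ring carbon. Among the compounds with values here, no measured step bears directly on shortening this chain; the one step available, a 1.5-fold lower number from compound 1 to compound 2 (0.17 log units; within the scatter), changed the chain end and was within the scatter. With nothing to point either way, compound 3 is expected to sit close to compound 2, the step of a 1.1-fold higher number from compound 2 to compound 3 (0.05 log units; within the scatter) being an estimate of no change beyond the scatter. For compound 3 the estimate in this assay is 30000 nM, within 10000 nM to 90000 nM.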

Compound 3, concentration for 50% growth inhibition: 31000 nM
Beside the measured number, compound 3's estimate is 1.0-fold (0.01 log units) below it; measured number inside the range.
By their numbers in this assay, from the lowest: compounds 2, 3 and 1 (each within the scatter of the next).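

In this assay, 3-hydroxyprop-1-en-1-yl in place of 4-hydroxybut-2-en-1-yl on the saturated ring carbon gives a 1.1-fold higher number from compound 2 to compound 3 (0.06 log units; within the scatter), so this change in chain length is not resolved at this position. Against formylmethyl at the same carbon, the same group gives a 1.3-fold lower number from compound 1 to compound 3 (0.11 log units; within the scatter), so all three side chains now stand within the scatter of one another, whereas the earlier compounds offered only a single comparison. No independent data bear on these numbers.

As far as these compounds go, whether an amine or a carboxylic acid at the chain end, or a longer chain, would give a step beyond the scatter stays open. Also open, from the compounds shown here alone, is whether a free hydroxyl in place of the silyl ether on the shared core would separate these compounds in this assay.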